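From Methoxy to Hydroxy: Estimating Compound 4

The compounds below may be only part of what the source reports. "The series", "measured", "known", "first", "only" and "open" are said of these compounds alone.

Of the compounds shown here, three have been measured in an assay on liver for inhibition of sterol O-acyltransferase 1 (Rattus norvegicus), using microsomes; on this read-out higher numbers stand for weaker inhibition and lower numbers for stronger inhibition.

- Compound 1, `CC(C)c1cccc(C(C)C)c1OC(=O)NS(=O)(=O)N(Cc1ccccc1)Cc1ccccc1`, gives 20000 nM.
- Compound 2, `CCCCCCCCCCN(CCCCCCCCCC)S(=O)(=O)NC(=O)Oc1c(C(C)(C)C)cc(C)cc1C(C)(C)C`, gives 89000 nM.
- Compound 3, `COc1cc(C(C)C)c(OC(=O)NS(=O)(=O)Oc2c(C(C)C)cccc2C(C)C)c(C(C)C)c1`, is known only as a limit of the assay, > 25000 nM.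

Compound 3 therefore has no exact number: the reading tells only that inhibition was too weak to be resolved, and the limit of > 25000 nM in this assay, at which 1 of the 3 values shown sits, marks it as the single limit among the three values. Among the compounds with values here, compound 1 and compound 2 both sit at weak inhibition as well, so the whole set so far is weak, and no step between measured compounds is available to show how any single change shifts this assay.

Compound 4, `CC(C)c1cc(O)cc(C(C)C)c1OC(=O)NS(=O)(=O)Oc1c(C(C)C)cccc1C(C)C`, differs from compound 3 in one place: hydrogen in place of methyl on an oxygen on an aromatic ring. Within the data shown here, with no measured step of this kind to lean on, the expected change from compound 3 to compound 4 is an at least 1.6-fold lower number from compound 3 to compound 4 (0.22 log units; that floor lies within the scatter), a modest gain in inhibition that could still fall within the scatter of repeated measurements. Compound 4 is estimated at 15000 nM, with a likely range from 4000 nM to 60000 nM, and a fair chance that this assay again reports only a limit.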

Compound 4, half-maximal inhibitory concentration: > 50000 nM
Compound 4: a limit, no number; the forecaster's own chance of this, stated with the estimate: 45%; middle value at least 3.3-fold (0.52 log units) away from the limit.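

In this assay, compound 3 and compound 4 each give only a limit of the assay rather than an exact number, and the change from methoxy to hydroxy between them cannot be read as a step. The compounds shown leave open whether this change shifts inhibition at all, by how much, and in which direction.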